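Same Sulfonyl Ring, a Different Halogen

The compounds below may be only part of what the source reports. "The series", "measured", "known", "first", "only" and "open" are said of these compounds alone.

Compound 1 `CCOC(=O)c1oc2ccc(N(Cc3ccccc3)S(=O)(=O)c3cccc(Br)c3)cc2c1C` carries a benzyl group and a (3-bromophenyl)sulfonyl group on one sulfonamide nitrogen attached to the shared core. In a functional assay on HCT-116 cells (Homo sapiens) for inhibition, read by MTT assay, with a stated time of 72 h (a lower number here means a stronger inhibitor, a higher number a weaker inhibitor), compound 1 gives > 40000 nM, which is a limit of the assay rather than a measured number. Compound 2 `CCOC(=O)c1oc2ccc(N(Cc3ccccc3)S(=O)(=O)c3ccc(OC)cc3)cc2c1C` has a 4-methoxyphenyl in place of the 3-bromophenyl on the sulfonyl sulfur. In this assay compound 2 gives > 40000 nM, again a limit. The step that the two limits leave unreadable from compound 1 to compound 2 is therefore unreadable. Compound 3 `CCOC(=O)c1oc2ccc(N(Cc3ccccc3)S(=O)(=O)c3ccc(Cl)cc3)cc2c1C` is the unmeasured partner, with the change (4-chlorophenyl in place of 3-bromophenyl on a sulfonyl sulfur). Going by the values given here, no measured step bears directly on this change, and the only guidance is the limit of > 40000 nM in this assay, at which 2 of the 2 values shown sit, so no step beyond the scatter in either direction is expected, and a limit is the likeliest outcome once more. Compound 3 is estimated at 60000 nM with a range from 20000 nM to 200000 nM, an expected step that the limit leaves unreadable from compound 1 to compound 3 that amounts to staying at the limit.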

Compound 3, half-maximal inhibitory concentration: 4860 nM
Beside the measured number, compound 3's estimate is 12-fold (1.09 log units) above it; the measured number lies below the stated range.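

This change gives the first readable difference among the sulfonyl aryl groups in this assay: replacing the 3-bromophenyl with a 4-chlorophenyl produces an at least 8.2-fold lower number from compound 1 to compound 3 (0.91 log units; beyond the scatter). A similar gap separates the 4-methoxyphenyl and the 4-chlorophenyl, seen as an at least 8.2-fold lower number from compound 2 to compound 3 (0.91 log units; beyond the scatter), so chloro and methoxy are not interchangeable on that aromatic carbon in this series. Compound 3 is the only one of the three with a number rather than a limit: the limit of > 40000 nM in this assay, at which 2 of the 3 values shown sit.

The halogen and its place on the ring change together between compound 1 and compound 3, so the step cannot be assigned to either; a 3-chlorophenyl or a 4-bromophenyl would separate the two. As far as these compounds go, how an amine or a carboxylic acid on this ring would read also remains open.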